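Chloro for isopropyl: a note on compound 4

The source may hold more compounds than are shown below. What is called first, only, known or untested is meant among the compounds shown, and "the series" means these compounds.

compound 1 `Cc1cnc(Nc2ccc(C(C)C)cc2)nc1Nc1nc2ccccc2s1` — in a functional assay on MCF7 cells (Homo sapiens) for antiproliferative activity, read by MTT assay, with a stated time of 48 h (a higher number here means a weaker inhibitor, a lower number a stronger inhibitor), compound 1 reports a limit, not a number: > 50000 nM.
compound 2 `NS(=O)(=O)c1ccc(Nc2ncc(F)c(Nc3nc4ccccc4s3)n2)cc1` — in this assay compound 2 also reports a limit: > 50000 nM.
compound 3 `Cc1ccc2nc(Nc3nc(Nc4ccc(S(C)(=O)=O)cc4)ncc3F)sc2c1` — in this assay compound 3 likewise reports a limit: > 50000 nM.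

Compound 1 stands nowhere distinct on these numbers: its own result is a limit, and the two further values shown are limits as well (the limit of > 50000 nM in this assay, at which 3 of the 3 values shown sit). Compound 4 `Cc1cnc(Nc2ccc(Cl)cc2)nc1Nc1nc2ccccc2s1` differs from compound 1 in one place, (chloro in place of isopropyl on an aromatic carbon), that is, chloro in place of isopropyl on an aromatic carbon. Among the compounds with values here, no pair of measured compounds tells the size of such a change. With every value sitting at the limit, the expected step that the limit leaves unreadable from compound 1 to compound 4 is none beyond the scatter, and another limit is the likely outcome. For compound 4 the estimate is 60000 nM, ranging from 20000 nM to 200000 nM.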

Compound 4, half-maximal inhibitory concentration: > 50000 nM
Compound 4 gave a limit, no number; the forecaster's own chance of this, stated with the estimate: 85%; the middle value does not contradict the limit.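

In this assay no step can be read from compound 1 to compound 4, as both report only a limit: the limit of > 50000 nM in this assay, at which 4 of the 4 values shown sit.
The compounds shown leave open what chloro in place of isopropyl does to antiproliferative activity, and whether any compound in this series gives a readable value.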